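Acyl Piperidine Replaces Carbamoylpropyl Chain

The source may hold more compounds than are shown below. What is called first, only, known or untested is meant among the compounds shown, and "the series" means these compounds.

Compound 1 `Cc1cccc2c1nc(COc1ccc(Cl)cc1)n2CCCC1CCN(Cc2ccccc2)CC1` gives 109 nM in an assay on AV12 cells for binding affinity to Neuropeptide Y receptor type 1 (Homo sapiens); on this read-out lower numbers stand for stronger inhibition and higher numbers for weaker inhibition.
Compound 2 `Cc1cccc2c1nc(COc1ccc(Cl)cc1)n2CCCC1CCN(CCCC(N)=O)CC1` gives 88 nM in this assay.

Compound 2 stands at one end of these two numbers, with compound 1 within the scatter of it: a 1.2-fold lower number from compound 1 to compound 2 (0.09 log units; within the scatter). Compound 3 `Cc1cccc2c1nc(COc1ccc(Cl)cc1)n2CCCC1CCN(C(=O)CCN2CCCCC2)CC1` differs from compound 2 by (2-(piperidin-1-yl)ethyl)carbonyl in place of 3-carbamoylpropyl on an amine nitrogen in a ring. Within the data shown here, the single measured step touches the same ring nitrogen but swaps a different group, so it bears only loosely here, and it stayed within the scatter. The number for compound 3 is therefore expected to remain close to that of compound 2, a 1.4-fold higher number from compound 2 to compound 3 (0.13 log units; within the scatter). The estimate for compound 3 is 120 nM, between 40 nM and 400 nM.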

Compound 3, inhibition constant: 260 nM
Compound 3: middle estimate off by 2.2-fold (0.34 log units), on the low side; the measured number falls inside the stated range.
By their numbers in this assay, from the lowest: compounds 2 and 1 (each within the scatter of the next); then compound 3.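

Unlike the earlier swap of benzyl for 3-carbamoylpropyl, which stayed within the scatter, (2-(piperidin-1-yl)ethyl)carbonyl on this amine nitrogen in a ring moves the number beyond the scatter, with a 3.0-fold higher number from compound 2 to compound 3 (0.47 log units; beyond the scatter) and a 2.4-fold higher number from compound 1 to compound 3 (0.38 log units; beyond the scatter) as its two modest steps. This position is therefore not indifferent to the group it carries. Nothing available accounts for this shift.

The compounds shown leave open whether the carbonyl or the piperidine ring drives the change. A 2-(piperidin-1-yl)ethyl group without the carbonyl, or a dimethylamino group in place of the piperidine ring, would separate the two.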